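The source may report more compounds than this note shows. Statements on the series, on what has been measured and on what is new or still open speak of the compounds shown alone.

Among the measured compounds shown here, in a functional assay (mast cells) for inhibition, with Rattus norvegicus as the target (a higher number here means that more compound is needed for the effect, a lower number that less compound is needed), compound 2 (`CCOC(=O)c1cnc2n(c1=O)C(C)CC/C2=N\Nc1cccc(C(=O)O)c1`) stands at 740000 nM as the highest of the two numbers so far, with compound 1 (`CCOC(=O)c1cnc2n(c1=O)C(C)CC/C2=N\Nc1ccccc1C(=O)O`) at 100000 nM as its only neighbour. Compound 3 (`CCOC(=O)c1cnc2n(c1=O)C(C)CC/C2=N\Nc1ccc(C(=O)O)cc1`) differs from compound 2 as follows: 4-carboxyphenyl in place of 3-carboxyphenyl on an amine nitrogen with 4-carboxyphenyl in place of 3-carboxyphenyl on an amine nitrogen. For the measured compounds named here, only one measured step swaps one carboxyphenyl for another (a 7.4-fold higher number from compound 1 to compound 2 (0.87 log units; beyond the scatter)) and it is modest but beyond the scatter. One step sets no trend, so in this assay a change of similar or smaller size is expected, leaning towards a lower number. The expected change is a 1.9-fold lower number from compound 2 to compound 3 (0.27 log units; within the scatter) on this estimate. Compound 3 is estimated at 400000 nM (expected range 90000 nM to 1500000 nM).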

Compound 3, half-maximal effective concentration: 66000 nM
Compound 3: middle estimate off by 6.1-fold (0.78 log units), on the high side, outside the stated range (below it).
By their numbers in this assay, from the lowest: compounds 3 and 1 (each within the scatter of the next); then compound 2.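

In this assay, moving the acid around the phenyl ring on the amine nitrogen gives a larger shift than the first pair showed: an 11-fold lower number from compound 2 to compound 3 (1.05 log units; beyond the scatter). In contrast, a 1.5-fold lower number from compound 1 to compound 3 (0.18 log units; within the scatter), so 2-carboxyphenyl and 4-carboxyphenyl are not separated, and among these three only 3-carboxyphenyl stands apart. Nothing at hand explains why this one placement differs.

From the compounds shown here alone, it remains open whether the carboxylic acid itself is needed for the effect, as an amide or a tetrazole in its place would show. The three compounds also leave open how an unsubstituted phenyl compares.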